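Chain-carbon substituent series: expectation for compound 4

This account rests on a few compounds, and the source may have more. Where it says the series, first, only, none or still open, it means among the compounds named here.

Measured so far in an assay on CHO cells for displacement of a labelled ligand from prostaglandin E2 receptor EP3 subtype (Homo sapiens), read by radioligand binding; on this read-out higher numbers stand for weaker inhibition and lower numbers for stronger inhibition:
compound 1 `CC(C)C(Cc1nnc[nH]1)c1ccc(-c2ccc3cccc(F)c3c2)[nH]c1=O` gives 10 nM
compound 2 `CC(C)C(Nc1nccs1)c1ccc(-c2ccc3cccc(F)c3c2)[nH]c1=O` gives 9.4 nM
compound 3 `CC(C)C(c1cnc(N)s1)c1ccc(-c2ccc3cccc(F)c3c2)[nH]c1=O` gives 16 nM

Compound 3 carries the highest of the three numbers, but both of its neighbours sit within the scatter: a 1.6-fold higher number from compound 1 to compound 3 (0.20 log units; within the scatter) and a 1.7-fold higher number from compound 2 to compound 3 (0.23 log units; within the scatter). Compound 1 and compound 2 are likewise indistinguishable, a 1.1-fold lower number from compound 1 to compound 2 (0.03 log units; within the scatter). Across these three compounds the group on the chain carbon has been exchanged without any step beyond the scatter in this assay.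

Compound 4 `CC(C)C(Cc1noc(=O)[nH]1)c1ccc(-c2ccc3cccc(F)c3c2)[nH]c1=O` differs from compound 3 by a group of 7 heavy atoms (3 carbon, 2 nitrogen, 2 oxygen; one five-membered aromatic ring with 3 hetero atoms) in place of a group of 6 heavy atoms (3 carbon, 2 nitrogen, 1 sulfur; one five-membered aromatic ring with 2 hetero atoms), on a saturated chain carbon bound to an aromatic carbon and a saturated chain carbon. For the measured compounds named here, no measured step covers this exact group; the three steps above are the ones that bear on it, and all of them are small. The expectation is therefore a step of no more than the scatter, a 1.3-fold lower number from compound 3 to compound 4 (0.12 log units; within the scatter), in either direction. Compound 4 is expected to give 12 nM in this assay, with a range of 5 nM to 30 nM.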

Compound 4, inhibition constant: 34 nM
The estimate for compound 4 lay 2.8-fold (0.45 log units) below the measured number; measured number above the stated range.
By their numbers in this assay, from the lowest: compounds 2, 1 and 3 (each within the scatter of the next); then compound 4.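

In this assay, for the compounds shown here, this position is no longer indifferent to the exchange: compound 4 is the first compound to stand beyond the scatter from every other, with a 2.1-fold higher number from compound 3 to compound 4 (0.33 log units; beyond the scatter) and a 3.6-fold higher number from compound 2 to compound 4 (0.56 log units; beyond the scatter). The step that stays within one ring type is a 3.4-fold higher number from compound 1 to compound 4 (0.53 log units; beyond the scatter): both groups are five-membered aromatic rings with 3 hetero atoms on a saturated chain carbon, two bonds along the chain from an aromatic carbon, so that ring type and placement alone do not secure the numbers of compound 1. Nothing available explains the shift.

Which atoms of the entering ring carry the step remains open. Also open, going by these compounds, is whether a tetrazol-5-yl group or a carboxylic acid at this place would fall with compound 1 or with compound 4.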